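A few compounds are considered here, and "the series" means these few. Any claim that something is new, unique, unknown or untested is made for them only; others in the source may bear on it.

Measured compounds:
compound 1 `CCn1cc(-c2nc3ccc(Cl)cc3[nH]2)c(=O)c2cc(F)c(N3CCNCC3)nc21`: 10300 nM
compound 2 `CCn1cc(-c2nc3ccc(Cl)cc3[nH]2)c(=O)c2cc(F)c(N3CCNCC3)cc21`: 1600 nM
compound 3 `CCn1cc(-c2nc3ccc([N+](=O)[O-])cc3[nH]2)c(=O)c2cc(F)c(N3CCNCC3)cc21`: 1100 nM

Three compounds were tested in a functional assay on KB cells (Homo sapiens) for cytotoxicity, read by MTT assay, with a stated time of 48 h; on this read-out higher numbers stand for weaker inhibition and lower numbers for stronger inhibition. Compound 1 gives the highest number of the three, with compound 2 nearest and compound 3 furthest; both gaps lie beyond the scatter. The difference between the core of compound 1 and the core of compound 2 is not broken down here. Compound 2 and compound 3 share a core and differ in one place, (nitro in place of chloro on an aromatic carbon), and this change made a 1.5-fold lower number from compound 2 to compound 3 (0.16 log units; within the scatter).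

Compound 4 `CCn1cc(-c2nc3ccc([N+](=O)[O-])cc3[nH]2)c(=O)c2cc(F)c(N3CCNCC3)nc21` has not yet been measured in this assay. It is related to compound 1 by nitro in place of chloro on an aromatic carbon, which is the same change as that from compound 2 to compound 3, made on the core of compound 1 instead. Since the earlier step stayed within the scatter, a step of similar size is expected here, though it is seen only once and on a different core, so the expectation carries some uncertainty. The estimated step is a 1.4-fold lower number from compound 1 to compound 4 (0.14 log units; within the scatter), resting on compound 1 at 10300 nM and on the step seen between compound 2 and compound 3. Compound 4 is therefore expected to give about 7500 nM, with a likely range from 3000 nM to 20000 nM.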

Compound 4, half-maximal inhibitory concentration: 22400 nM
Compound 4: the middle estimate sits 3.0-fold (0.48 log units) below what was measured; the whole stated range lies below it.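

In this assay, nitro in place of chloro on an aromatic carbon gave a 2.2-fold higher number from compound 1 to compound 4 (0.34 log units; beyond the scatter), a modest step but one that stands clear of the usual variation between repeats. Set beside the earlier case, this shows that the change does not give the same result on both cores, so the step seen on one core could not simply be transferred to the other: the same change on two cores in this assay, a 1.5-fold lower number (0.16 log units; within the scatter) from compound 2 to compound 3 and a 2.2-fold higher number (0.34 log units; beyond the scatter) from compound 1 to compound 4, 3.2-fold (0.50 log units) apart, beyond the scatter of two such steps

The comparison rests on a single pair of compounds for each core, so it shows only that the outcome of this exchange depended on the core in these two cases; it does not show how the exchange would behave on any further core, nor which difference between the two cores lies behind the gap.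

The compounds shown leave open whether other groups on the same aromatic carbon, such as an amine, a carboxylic acid or a methyl group, would also give results that differ between the two cores. They also leave open whether a bare hydrogen at that carbon would give a number close to those of the chloro and nitro compounds on each core.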